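Phenoxy to benzyloxy on the amide aryl: cytotoxicity outlook

The source may report more compounds than this note shows. Statements on the series, on what has been measured and on what is new or still open speak of the compounds shown alone.

Measured so far:
compound 1 `NC(=O)c1c(NC(=O)c2ccc(Cl)cc2)sc2c1CCN(C(=O)c1ccccc1)C2`: 42.5%
compound 2 `NC(=O)c1c(NC(=O)c2ccc(Oc3ccccc3)cc2)sc2c1CCN(C(=O)c1ccccc1)C2`: 4.71%

In an ADME assay on RAW264.7 cells (Mus musculus) for cytotoxicity, read by MTT assay, with a stated time of 48 h, tested at 50 uM (on this read-out higher numbers stand for more inhibition at the one concentration tested (going by the name of the read-out) and lower numbers for less inhibition), compound 1 gives 42.5%, while compound 2 gives 4.71%, the lowest of the two numbers. Going by the values given here, the only measured step is a number 37.8 percentage points lower from compound 1 to compound 2 (beyond the scatter). Compound 3 `NC(=O)c1c(NC(=O)c2ccc(OCc3ccccc3)cc2)sc2c1CCN(C(=O)c1ccccc1)C2` differs from compound 2 by benzyl in place of phenyl on an oxygen on an aromatic ring. Among the compounds with values here, no measured step covers benzyl for phenyl, so the chloro-to-phenoxy step offers only indirect guidance, suggesting that a larger aryl ether keeps inhibition low. Compound 3 is therefore expected to move little, a number 5.3 percentage points higher from compound 2 to compound 3 (within the scatter). The estimate for compound 3 is 10%, between 0% and 30%.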

Compound 3, a percentage reported as inhibition, at one concentration (the size of the read-out at that concentration, not a potency): 13.7%
Compound 3: middle estimate off by 3.7 percentage points, on the low side, and the stated range covers the measured number.
By their numbers in this assay, from the lowest: compounds 2 and 3 (each within the scatter of the next); then compound 1.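

The change from phenoxy to benzyloxy gives a number 9 percentage points higher from compound 2 to compound 3 (within the scatter) and so does not separate the two aryl ethers. Going by these compounds alone, replacing the chloro group with benzyloxy gives a number 28.8 percentage points lower from compound 1 to compound 3 (beyond the scatter) and makes a second ether that stands clear of the chloro compound, with no compound here going against that. No supporting data bear on the cause of these differences.

Still open, on these data alone, is whether an amine or a carboxylic acid at this position would stay as low as compound 2 and compound 3. A longer chain between the oxygen and the phenyl ring is equally untested by these numbers.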